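A Furan Replaces the Methoxyphenyl at the Saturated Carbon

The source may hold more compounds than are shown below. What is called first, only, known or untested is meant among the compounds shown, and "the series" means these compounds.

Measured compounds:
compound 1 `COc1ccc(C2C(C#N)=C(N)N(c3cc(OC)c(OC)c(OC)c3)C3=C2C(=O)CC(C)(C)C3)cc1`: 1%
compound 2 `COc1ccccc1C1C(C#N)=C(N)N(c2cc(OC)c(OC)c(OC)c2)C2=C1C(=O)CC(C)(C)C2`: 65%

In a functional assay on Ehrlich cells (Mus musculus) for cytotoxicity, tested at 25 ug/mL (on this read-out higher numbers stand for a stronger effect at the one concentration tested and lower numbers for a weaker effect), compound 2 gives 65% and stands highest of the two numbers; compound 1 gives 1%. For the measured compounds named here, the single measured step between them is a number 64 percentage points higher from compound 1 to compound 2 (beyond the scatter), a swap of one aryl group for another at the same saturated ring carbon.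

Compound 3 `COc1cc(N2C(N)=C(C#N)C(c3ccc(C)o3)C3=C2CC(C)(C)CC3=O)cc(OC)c1OC` is not yet measured. It differs from compound 2 in that (5-methylfuran-2-yl in place of 2-methoxyphenyl on a saturated ring carbon).

Going by the values given here, only the step from compound 1 to compound 2 bears on this change, since it alters the same saturated ring carbon, and it was large. It does not, however, involve a five-membered ring with a hetero atom, so the direction for compound 3 is open. The activity at this carbon can evidently shift widely, which argues for a wide range rather than a confident direction. Compound 3 is therefore expected to show a number 30 percentage points lower from compound 2 to compound 3 (beyond the scatter) in this assay. The estimate for compound 3 is 35%, within 3% to 70%.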

Compound 3, a percentage reported as activity, at one concentration (the size of the read-out at that concentration, not a potency): 31%
Compound 3: the middle estimate sits 4 percentage points above what was measured; the range from low to high includes it.
By their numbers in this assay, from the lowest: compound 1; then compound 3; then compound 2.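

In this assay, the 5-methylfuran-2-yl group at the saturated ring carbon gives a number 34 percentage points lower from compound 2 to compound 3 (beyond the scatter), and set against the other aryl group it gives a number 30 percentage points higher from compound 1 to compound 3 (beyond the scatter). Compound 3 therefore ranks above compound 1 and under compound 2, which shows that this position can keep a clear effect with a five-membered aromatic ring with one hetero atom, not only with a six-membered aromatic ring of carbon only, while that furan does not reach the level of the 2-methoxyphenyl group. Nothing available explains why the three groups order in this way.

As far as these compounds go, the three compounds cannot separate the part played by the methyl group of 5-methylfuran-2-yl from that of the furan ring itself, so it remains open how a plain furan-2-yl or a thiophen-2-yl group would read at this carbon. Also open, from the compounds shown here alone, is whether the high value of compound 2 depends on the methoxy group as such, which a 2-hydroxyphenyl or 2-chlorophenyl group at the same carbon would begin to test.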